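This account rests on a few compounds, and the source may have more. Where it says the series, first, only, none or still open, it means among the compounds named here.

In an assay on isolated protein for binding affinity to 5-hydroxytryptamine receptor 1D (Homo sapiens) (on this read-out higher numbers stand for weaker inhibition and lower numbers for stronger inhibition), compound 2 `CCCCNCc1ccc(Cl)c(-c2ccccc2OC)c1` gives 2000 nM, which is the highest of the two numbers recorded so far. Its nearest neighbour is compound 1 `CCNCc1ccc(Cl)c(-c2ccccc2OC)c1`, which in this assay gives 220 nM. Within the data shown here, the only step between measured compounds that is known runs a 9.1-fold higher number from compound 1 to compound 2 (0.96 log units; beyond the scatter), and it bears directly on the question at hand, since compound 3 `CCCNCc1ccc(Cl)c(-c2ccccc2OC)c1` sits between them on the same chain. Compound 3 differs from compound 2 by hydrogen in place of methyl on a saturated chain carbon, three bonds along the chain from an amine nitrogen, so that the butyl group of compound 2 becomes a propyl group. Cutting the chain back by a single carbon undoes part of the lengthening that produced the step from compound 1 to compound 2, and that step was modest but beyond the scatter. A shortening of the chain by one carbon is therefore expected to give a lower number in this assay, with the step from compound 2 to compound 3 estimated at a 2.9-fold lower number from compound 2 to compound 3 (0.46 log units; beyond the scatter). On that basis compound 3 is expected to give about 700 nM in this assay, with a likely range from 250 nM to 2000 nM.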

Compound 3, inhibition constant: 220 nM
Beside the measured number, compound 3's estimate is 3.2-fold (0.50 log units) above it; the whole stated range lies above it.
By their numbers in this assay, from the lowest: compounds 1 and 3 (each within the scatter of the next); then compound 2.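

In this assay, replacing methyl with hydrogen on a saturated chain carbon, three bonds along the chain from an amine nitrogen, gives a 9.1-fold lower number from compound 2 to compound 3 (0.96 log units; beyond the scatter) and takes back the whole of the rise seen with the butyl group, while the shorter pair shows no change at the digits printed from compound 1 to compound 3 (within the scatter) and so stands level. Among these three compounds, the number therefore does not climb evenly with chain length: going from ethyl to propyl leaves it within the scatter, and the step beyond the scatter appears only on going from propyl to butyl. Nothing available explains why this one carbon separates compound 2 from compound 3.

The compounds shown leave open whether a pentyl chain would stay near compound 2 or move further, so it is unknown if the butyl result marks a plateau or part of a continuing rise. They also leave open whether the limit depends on chain length alone, which a branched isobutyl group or a butyl chain ending in a hydroxyl group could help to separate.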